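Nitrile to Nitro on a Shared Amide Scaffold

The compounds below may be only part of what the source reports. "The series", "measured", "known", "first", "only" and "open" are said of these compounds alone.

Compound 1 `C/C=C/C(=O)Nc1c(C(O)(C(F)(F)F)C(F)(F)F)ccc2ccccc12` reaches 96% in a functional assay (Sus scrofa) with sulfonylurea receptors; K-ATP channels (Homo sapiens) as the target; on this read-out lower numbers stand for smaller maximal responses and higher numbers for larger maximal responses. Compound 2 `N#Cc1cccc(C(=O)Nc2c(C(O)(C(F)(F)F)C(F)(F)F)ccc3ccccc23)c1` reaches 96% in this assay, so no change at the digits printed from compound 1 to compound 2 (within the scatter), and compound 2 stands level with compound 1 on the numbers shown. Compound 3 `O=C(Nc1c(C(O)(C(F)(F)F)C(F)(F)F)ccc2ccccc12)c1cccc([N+](=O)[O-])c1` has not been measured; it differs from compound 2 by nitro in place of cyano on an aromatic carbon, the same difference cut one bond further out reading 3-cyanophenyl to 3-nitrophenyl. Among the measured compounds shown here, the one measured step, exchanging prop-1-en-1-yl for 3-cyanophenyl, left the maximal response unchanged, and a smaller exchange on that same ring is expected to behave alike, a number 2 percentage points lower from compound 2 to compound 3 (within the scatter). Compound 3 is therefore estimated at 94%, between 82% and 102%.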

Compound 3, largest response reached (reported as efficacy), in percent of the reference or control that the assay uses: 99%
Estimate against measurement, compound 3: 5 percentage points below; measured number inside the range.
By their numbers in this assay, from the lowest: compounds 1, 2 and 3 (each within the scatter of the next).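

At this aromatic carbon, meta to a large group, nitro in place of cyano gives a number 3 percentage points higher from compound 2 to compound 3 (within the scatter) in this assay, so a second group at this position joins the nitrile without a step beyond the scatter. The exchange of prop-1-en-1-yl for 3-nitrophenyl on the carbonyl carbon gives a number 3 percentage points higher from compound 1 to compound 3 (within the scatter), which matches what 3-cyanophenyl showed. Nothing available explains this sameness. Whether an amine or a carboxylic acid on this aromatic carbon would move the maximal response remains open, since no group shown here produces a step beyond the scatter.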